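Swapping the aryl ketone on a trimethoxyphenyl pyrazole chalcone

A few compounds are considered here, and "the series" means these few. Any claim that something is new, unique, unknown or untested is made for them only; others in the source may bear on it.

Measured so far:
compound 1, `COc1cc(-c2cc(/C=C/C(=O)c3ccc(N)cc3)[nH]n2)cc(OC)c1OC`: 13400 nM
compound 2, `COc1ccc(-c2cc(/C=C/C(=O)c3cc(OC)c(OC)c(OC)c3)[nH]n2)cc1OC`: 22300 nM
compound 3, `COc1ccc(-c2cc(/C=C/C(=O)c3ccc(N)cc3)[nH]n2)cc1`: 15400 nM

In a functional assay on A498 cells (Homo sapiens) for inhibition, read by sulforhodamine B assay, with a stated time of 48 h (a lower number here means that less compound is tolerated, a higher number that more compound is tolerated), compound 1 gives 13400 nM, the lowest of the three numbers, yet compound 3 at 15400 nM and compound 2 at 22300 nM both sit within the scatter of it, so no ordering among them can be claimed. Compound 4, `COc1ccc(C(=O)/C=C/c2cc(-c3cc(OC)c(OC)c(OC)c3)n[nH]2)cc1OC`, has not been measured in this assay. It differs from compound 1 in one place: 3,4-dimethoxyphenyl in place of 4-aminophenyl on a carbonyl carbon. The three measured compounds, with different aryl groups on the carbonyl carbon, all land within the scatter of one another, so no step beyond the scatter is expected in this assay in either direction. Compound 4 is therefore estimated at 18000 nM, between 7000 nM and 45000 nM, a step of a 1.3-fold higher number from compound 1 to compound 4 (0.13 log units; within the scatter).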

Compound 4, concentration lethal to 50% of the cells: 6000 nM
Estimate against measurement, compound 4: 3.0-fold (0.48 log units) above; measured number outside the range, below it.
By their numbers in this assay, from the lowest: compound 4; then compounds 1, 3 and 2 (each within the scatter of the next).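

In this assay the exchange of 4-aminophenyl for 3,4-dimethoxyphenyl on a carbonyl carbon gives a 2.2-fold lower number from compound 1 to compound 4 (0.35 log units; beyond the scatter), a modest step but the first beyond the scatter. The earlier compounds shown here, all within the scatter of one another, could not show that the aryl group at this place can move the number, or in which direction. Nothing available accounts for the step. Still open, as far as these compounds go, is whether a single methoxy group or a hydroxyl group on that phenyl ring would give a similar number. Whether a morpholine or a carboxylic acid there would be tolerated also remains unanswered.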